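The compounds below may be only part of what the source reports. "The series", "measured", "known", "first", "only" and "open" are said of these compounds alone.

Compound 1 `O=C(Nc1ccc(F)cc1)c1c(NO)cc(-c2cccs2)oc1=O` and compound 2 `O=C(Nc1ccc(Br)cc1)c1c(NO)cc(-c2cccs2)oc1=O` share one core and differ only in the group on the aromatic ring attached to the amide nitrogen. In an ADME assay on Huh-7 cells (Homo sapiens) for cytotoxicity, with a stated time of 3 days (on this read-out higher numbers stand for lower toxicity in this test and lower numbers for higher toxicity in this test), compound 1 gives a value that is a limit of the assay, > 20000 nM. Compound 2 likewise gives only a limit in this assay, > 20000 nM. The step that the two limits leave unreadable from compound 1 to compound 2 is therefore not readable: both measurements stop at the same boundary, which is the limit of > 20000 nM in this assay, at which 2 of the 2 values shown sit, so compound 2 stands at that boundary and no further up or down. Compound 3 `Cc1cccc(NC(=O)c2c(NO)cc(-c3cccs3)oc2=O)c1` has not yet been measured. The change from compound 2 to compound 3 is 3-methylphenyl in place of 4-bromophenyl on an amide-type nitrogen. Among the compounds with values here, the only measured step bears on the same amide nitrogen, but since it could not be sized, it gives no direction for the new change. The expectation for compound 3 rests on (the limit of > 20000 nM in this assay, at which 2 of the 2 values shown sit), at which every measured value sits, so the estimated step that the limit leaves unreadable from compound 2 to compound 3 is none beyond the scatter. Compound 3 is therefore expected to give about 30000 nM in this assay, within a range of 15000 nM to 80000 nM.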

Compound 3, half-maximal cytotoxic concentration: > 20000 nM
Compound 3: no number, only a limit (the forecaster's own chance of this, stated with the estimate: 85%); the middle value does not contradict the limit.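

Compound 3 gives > 20000 nM in this assay, which is a limit of the assay and not a number, so neither its step from compound 1 nor its step from compound 2 can be read: the limit of > 20000 nM in this assay, at which 3 of the 3 values shown sit.

The compounds shown leave open whether the three differ at all in toxicity to these cells, and at what concentration any of them would become toxic.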